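The source may report more compounds than this note shows. Statements on the series, on what has been measured and on what is new or still open speak of the compounds shown alone.

Measured compounds in an assay on CHO cells for displacement of a labelled ligand from transient receptor potential cation channel subfamily V member 1 (Homo sapiens), read by scintillation counting, with a stated time of 60 min; on this read-out lower numbers stand for stronger inhibition and higher numbers for weaker inhibition:
- compound 1 `CN(C)C1(Cc2ccccc2)CCN(c2cc(C(F)(F)F)ccc2CNC(=O)Nc2ccc(CNS(C)(=O)=O)c(F)c2)CC1` gives 16.4 nM
- compound 2 `CN(C)C1(Cc2ccccc2)CCN(c2cc(C(F)(F)F)ccc2CNC(=O)NCc2ccc(NS(C)(=O)=O)c(F)c2)CC1` gives 266 nM
- compound 3 `CN(C)C1(Cc2ccccc2)CCN(c2cc(C(F)(F)F)ccc2CNC(=O)Nc2cccc3ccc(O)cc23)CC1` gives 0.46 nM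

Compound 3 stands lowest of the three numbers in this assay; the nearest is compound 1, and compound 2 lies furthest, both separated from compound 3 by more than the scatter. Compound 4 `CN(C)C1(Cc2ccccc2)CCN(c2cc(C(F)(F)F)ccc2CNC(=O)Nc2ccc3cccnc3c2)CC1` has not been measured. It differs from compound 3 by quinolin-7-yl in place of 7-hydroxynaphthalen-1-yl on an amide-type nitrogen. Among the measured compounds shown here, no pair of measured compounds shows this change, so the step has no direct precedent in the set; compounds 1 and 2 differ from compound 3 at the same position by larger rearrangements and give no guide to a single-ring swap. The expected step from compound 3 to compound 4 is an 11-fold higher number from compound 3 to compound 4 (1.04 log units; beyond the scatter), toward a higher number and beyond the scatter. Compound 4 is estimated at 5 nM, with a range from 1 nM to 30 nM.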

Compound 4, inhibition constant: 14.1 nM
Compound 4: middle estimate off by 2.8-fold (0.45 log units), on the low side; low and high end bracket the measured number.
By their numbers in this assay, from the lowest: compound 3; then compounds 4 and 1 (each within the scatter of the next); then compound 2.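

Replacing 7-hydroxynaphthalen-1-yl with quinolin-7-yl on the amide-type nitrogen gives a 31-fold higher number from compound 3 to compound 4 (1.49 log units; beyond the scatter) in this assay, so one group change at this position moves the number beyond the scatter. The entering group has 0 hydrogen-bond donors where the leaving group has 1, but it also brings a ring nitrogen, and this single step cannot separate the two changes. Nothing available explains the step.

Open, going by these compounds, is whether an amine in place of the hydroxyl on the naphthalene keeps the number of compound 3 0.46 nM in this assay, and whether a carboxylic acid there does.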